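The source may hold more compounds than are shown below. What is called first, only, known or untested is meant among the compounds shown, and "the series" means these compounds.

Among the compounds with values here, compound 1 `Cc1ccccc1-n1c(Nc2nc(-c3ccc(Br)cc3)cs2)n[nH]c1=S` is one of three compounds measured in a functional assay on the whole organism (strain Swiss albino) for inhibition, with Mus musculus as the target, with a stated time of 0.5 h (a higher number here means that more compound is needed for the effect, a lower number that less compound is needed), where compound 1 gives 100 mg/kg. Compound 2 `Cc1ccccc1-n1c(Nc2nc(-c3ccc([N+](=O)[O-])cc3)cs2)n[nH]c1=S` gives 100 mg/kg in this assay, and compound 3 `COc1ccc(-n2c(Nc3nc(-c4ccc(Cl)cc4)cs3)n[nH]c2=S)cc1` gives 300 mg/kg. Compound 1 therefore stands level with compound 2, the two sharing the lowest number of the three, while compound 3 shows a number beyond the scatter above them. Within the data shown here, the only single-point step measured is no change at the digits printed from compound 1 to compound 2 (within the scatter), a change on the outer aromatic ring rather than on the group attached to the core nitrogen.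

The compound not yet measured is compound 4 `Cc1ccc(-n2c(Nc3nc(-c4ccc(Br)cc4)cs3)n[nH]c2=S)cc1`. The difference from compound 1 is 4-methylphenyl in place of 2-methylphenyl on an aromatic nitrogen. Among the measured compounds shown here, no measured step touches this position directly; the nearest hint is compound 3, which carries a 4-methoxyphenyl on the same nitrogen and shows a higher number, though it also differs elsewhere. Compound 4 is therefore expected to show a modest step of a 1.5-fold higher number from compound 1 to compound 4 (0.18 log units; within the scatter), and its value in this assay is estimated at 150 mg/kg, within a range from 75 mg/kg to 300 mg/kg.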

Compound 4, minimum effective dose: 300 mg/kg
Compound 4: the middle estimate sits 2.0-fold (0.30 log units) below what was measured, within the range that was stated.
By their numbers in this assay, from the lowest: compounds 1 and 2 (each within the scatter of the next); then compounds 3 and 4 (each within the scatter of the next).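

The group on the aromatic nitrogen is now shown to matter in this assay: moving the methyl group, with 4-methylphenyl in place of 2-methylphenyl, gives a 3.0-fold higher number from compound 1 to compound 4 (0.48 log units; beyond the scatter), although the two compounds have the same atoms, joined differently. The earlier single-place step, on the outer aromatic ring, was no change at the digits printed from compound 1 to compound 2 (within the scatter), so among these compounds only the change on the nitrogen substituent moves the number beyond the scatter. Nothing given here accounts for this shift.

The compounds shown leave open how the number would respond to a plain phenyl, a benzyl or a longer alkyl chain on this nitrogen. They also leave open whether an amine or a carboxylic acid on that aromatic ring would keep the lower number of compound 1 100 mg/kg.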